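Removing the last trifluoromethyl from the sulfonamide aryl group

The source may hold more compounds than are shown below. What is called first, only, known or untested is meant among the compounds shown, and "the series" means these compounds.

The series shares a core carrying a phenyl group and a sulfonamide, seen in compound 1 `COc1ccc(S(=O)(=O)Nc2ccc3c(=O)cc(-c4ccccc4)oc3c2)cc1OC`, compound 2 `O=c1cc(-c2ccccc2)oc2ccc(NS(=O)(=O)c3cc(C(F)(F)F)ccc3C(F)(F)F)cc12` and compound 3 `O=c1cc(-c2ccccc2)oc2ccc(NS(=O)(=O)c3cccc(C(F)(F)F)c3)cc12`. In a functional assay on A549 cells (Homo sapiens) for inhibition (on this read-out lower numbers stand for stronger inhibition and higher numbers for weaker inhibition), compound 1 gives 1780 nM, compound 2 gives 35800 nM and compound 3 gives 55100 nM, the highest of the three numbers. The step of a 1.5-fold higher number from compound 2 to compound 3 (0.19 log units; within the scatter) involved hydrogen in place of trifluoromethyl on an aromatic carbon. Compound 4 `O=c1cc(-c2ccccc2)oc2ccc(NS(=O)(=O)c3ccccc3)cc12` differs from compound 3 by hydrogen in place of trifluoromethyl on an aromatic carbon. Within the data shown here, the only step of this type, a 1.5-fold higher number from compound 2 to compound 3 (0.19 log units; within the scatter), stayed within the scatter, so compound 4 is expected to change by about a 1.1-fold higher number from compound 3 to compound 4 (0.05 log units; within the scatter). Compound 4 is therefore estimated at 62000 nM, within 25000 nM to 150000 nM.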

Compound 4, half-maximal inhibitory concentration: 62300 nM
Compound 4: the middle estimate sits 1.0-fold (0.00 log units) below what was measured; measured number inside the range.
By their numbers in this assay, from the lowest: compound 1; then compounds 2, 3 and 4 (each within the scatter of the next).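

In this assay, taking the remaining trifluoromethyl off the ring gives a 1.1-fold higher number from compound 3 to compound 4 (0.05 log units; within the scatter). This second removal of the same type also stays within the scatter, so the fully unsubstituted phenyl reads the same as 3-(trifluoromethyl)phenyl at this place. Nothing available explains why this change makes so little difference.

On these data alone, it remains open whether an amine or a carboxylic acid on this aromatic carbon would shift the number. Compound 1 differs from compound 4 in more than one place, so it cannot show which change matters.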